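The source may hold more compounds than are shown below. What is called first, only, known or untested is meant among the compounds shown, and "the series" means these compounds.

Measured so far:
compound 1 `COc1ccc(-c2noc(-c3ccc(F)cc3)n2)cc1O`: > 1000000 nM
compound 2 `COc1cc(-c2noc(-c3ccncc3)n2)ccc1OCc1ccccc1`: > 1000000 nM

In a functional assay on DU-145 cells (Homo sapiens) for antiproliferative activity, read by MTT assay, with a stated time of 24 h (a lower number here means a stronger inhibitor, a higher number a weaker inhibitor), compound 1 gives only a limit of the assay, > 1000000 nM. Compound 2 likewise gives only a limit, > 1000000 nM. Both values sit at the limit of > 1000000 nM in this assay, at which 2 of the 2 values shown sit, so compound 1 stands at the edge of what the assay reports, with no number beneath it. Compound 3 `COc1ccc(-c2noc(-c3ccc(F)cc3)n2)cc1OC1CCCC1` differs from compound 1 by cyclopentyl in place of hydrogen on an oxygen on an aromatic ring. Among the compounds with values here, no measured pair shows this change, so no step in this assay can be drawn for it. Compound 3 is expected to come out near 700000 nM, between 100000 nM and 1000000 nM, an expected step of an at least 1.4-fold lower number from compound 1 to compound 3 (0.15 log units; that floor lies within the scatter) that stays within the scatter.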

Compound 3, half-maximal inhibitory concentration: 20700 nM
For compound 3 the middle estimate is 34-fold (1.53 log units) above the measured one; measured number below the stated range.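

Replacing hydroxy with cyclopentyloxy on this oxygen on an aromatic ring gives the only result in this assay that is not a limit among the compounds shown, with an at least 48-fold lower number from compound 1 to compound 3 (1.68 log units; beyond the scatter) beyond the scatter. Compound 1 gives > 1000000 nM, which is a limit of the assay and not a number. Going by these compounds, the step is therefore a floor, and its true size stays unknown: the limit of > 1000000 nM in this assay, at which 2 of the 3 values shown sit. Still open, on these data alone, is whether an ethyl group, a longer chain or an amine-bearing chain on this oxygen would match cyclopentyl, and whether the ring itself matters.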